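The source may report more compounds than this note shows. Statements on the series, on what has been measured and on what is new or still open speak of the compounds shown alone.

Measured in a functional assay on the whole organism with Rattus norvegicus as the target (on this read-out lower numbers stand for an effect already at smaller amounts and higher numbers for an effect only at larger amounts of compound), so far:
Compound 1 `COc1cc(N)c(Cl)cc1C(=O)NCCN(C)CC1CCCCC1` gives 3 mg/kg
Compound 2 `COc1ccc(Cl)cc1C(=O)NCCN(C)Cc1ccccc1` gives 3 mg/kg
Compound 3 `COc1cc(N)c(Cl)cc1C(=O)NCC1CCC(C)N1Cc1ccccc1` gives 0.67 mg/kg

Compound 3 at 0.67 mg/kg has the lowest number of the three. Compound 1 stands at 3 mg/kg and compound 2 at 3 mg/kg in this series. The gap between compound 3 and each of these two lies beyond the scatter. Compound 4 `CNc1cc(OC)c(C(=O)NCC2CCC(C)N2Cc2ccccc2)cc1Cl` has not yet been measured. It departs from compound 3 by a single change methyl in place of hydrogen on a nitrogen on an aromatic ring that puts methyl in place of hydrogen on a nitrogen on an aromatic ring, turning amino to methylamino. For the measured compounds named here, no measured pair isolates this change, so no step beyond the scatter is expected, with a slight lean towards a lower number (estimated: a 1.3-fold lower number from compound 3 to compound 4 (0.13 log units; within the scatter)). For compound 4 the expected value is 0.5 mg/kg with a range from 0.15 mg/kg to 1.6 mg/kg in this estimate.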

Compound 4, dose for half-maximal effect: 0.35 mg/kg
Estimate against measurement, compound 4: 1.4-fold (0.15 log units) above, and the stated range covers the measured number.
By their numbers in this assay, from the lowest: compounds 4 and 3 (each within the scatter of the next); then compounds 1 and 2 (each within the scatter of the next).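

In this assay, putting methyl in place of hydrogen on a nitrogen on an aromatic ring gives a 1.9-fold lower number from compound 3 to compound 4 (0.28 log units; within the scatter), a step within the scatter. For the compounds shown here, this is the first pair that isolates amino to methylamino, and at this place the added methyl leaves the two numbers indistinguishable. No available evidence bears on this result.

Going by these compounds, what an ethyl or an acetyl on this nitrogen would do remains open. So does whether the same methyl step would read alike on the core of compound 1.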